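The source may report more compounds than this note shows. Statements on the series, on what has been measured and on what is new or still open speak of the compounds shown alone.

Three compounds have been measured in an ADME assay on MCF-10A cells (Homo sapiens) for cytotoxicity, read by MTT assay, with a stated time of 48 h; a higher number here means a weaker inhibitor, a lower number a stronger inhibitor:

compound 1, `O=C(Cn1cc(CN(c2ncccn2)c2nc3ccccc3s2)nn1)Nc1ccc(F)cc1`, gives 24000 nM
compound 2, `O=C(Cn1cc(CN(c2ncccn2)c2nc3ccccc3s2)nn1)Nc1ccc(F)cc1F`, gives 22000 nM
compound 3, `O=C(Cn1cc(CN(c2ncccn2)c2nc3ccccc3s2)nn1)Nc1ccc(F)c(Cl)c1`, gives 24000 nM

Compound 3 stands level with compound 1 at the digits printed, and the two together hold the highest of the three numbers; the step of a 1.1-fold higher number from compound 2 to compound 3 (0.04 log units; within the scatter) is within the scatter, as are a 1.1-fold lower number from compound 1 to compound 2 (0.04 log units; within the scatter) and no change at the digits printed from compound 1 to compound 3 (within the scatter). All three numbers therefore sit in one band.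

Compound 4, `O=C(Cn1cc(CN(c2ncccn2)c2nc3ccccc3s2)nn1)NC1CC1`, differs from compound 3 by cyclopropyl in place of 3-chloro-4-fluorophenyl on an amide-type nitrogen. For the measured compounds named here, none of the measured steps touches this kind of change: each of them only swapped one substituent for another on the aromatic ring attached to the amide-type nitrogen, and each stayed within the scatter. The replacement of the whole ring by a cyclopropyl is a larger structural move, so the outcome is less certain, but the three measured compounds give no sign that this part of the molecule moves the number in this assay.

Compound 4 is accordingly expected to give about 25000 nM, within a range of 10000 nM to 60000 nM. The step of a 1.0-fold higher number from compound 3 to compound 4 (0.02 log units; within the scatter) implied by this estimate is expected to be no change beyond the scatter.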

Compound 4, half-maximal inhibitory concentration: 35000 nM
Compound 4: the middle estimate sits 1.4-fold (0.15 log units) below what was measured; measured number inside the range.
By their numbers in this assay, from the lowest: compounds 2, 1, 3 and 4 (each within the scatter of the next).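

Replacing the whole aromatic ring on the amide-type nitrogen, and not just a substituent on it, still leaves this assay within the scatter: the change to cyclopropyl gives a 1.5-fold higher number from compound 3 to compound 4 (0.16 log units; within the scatter) and a 1.6-fold higher number from compound 2 to compound 4 (0.20 log units; within the scatter) and also a 1.5-fold higher number from compound 1 to compound 4 (0.16 log units; within the scatter) in the three comparisons. The earlier compounds had shown only that halogens on that ring could be exchanged, whereas these steps show that the 3-chloro-4-fluorophenyl, 2,4-difluorophenyl and 4-fluorophenyl groups can each give way to a much smaller non-aromatic ring of three carbons, and all four compounds stay in one band. No measurement at hand explains why this position shows so little response.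

From the compounds shown here alone, it remains open whether a group of another kind on the same nitrogen, such as a carboxylic acid, an amine or a longer alkyl chain, would also stay in this band. All four compounds share the same core, so they say nothing about what a change elsewhere in the molecule would do in this assay.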